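A few compounds are considered here, and "the series" means these few. Any claim that something is new, unique, unknown or untested is made for them only; others in the source may bear on it.

Measured so far:
- compound 1 `N=C(N)c1ccc(-c2ccc(-c3ccc(Cl)cc3)s2)s1`: 320 nM
- compound 2 `N=C(N)c1ccc(-c2ccc(-c3ccc(F)cc3)o2)o1`: "not determined" (no result reported)

Among the compounds with values here, in a functional assay on SR cells (Homo sapiens) for inhibition, read by sulforhodamine B assay, with a stated time of 48 h (a higher number here means a weaker inhibitor of growth, a lower number a stronger inhibitor of growth), compound 1 gives 320 nM, the only number in the set, so it stands alone with nothing to rank it against; compound 2 carries "not determined" (no result reported). Compound 3 `N=C(N)c1ccc(-c2ccc(-c3ccc(F)cc3)s2)s1` is not yet measured. It differs from compound 1 by fluoro in place of chloro on an aromatic carbon. Within the data shown here, no step between measured compounds is available, so the direction rests on the change alone; a small shift toward weaker growth inhibition is expected, near the edge of the scatter. Compound 3 is estimated at 500 nM (range 200 nM to 1500 nM), which means an expected step of a 1.6-fold higher number from compound 1 to compound 3 (0.19 log units; within the scatter).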

Compound 3, concentration for 50% growth inhibition: 1170 nM
The estimate for compound 3 lay 2.3-fold (0.37 log units) below the measured number; the range from low to high includes it.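

In this assay the aromatic carbon para to a large group responds to the choice of halogen: fluoro in place of chloro gives a 3.7-fold higher number from compound 1 to compound 3 (0.56 log units; beyond the scatter) and so chloro is the better of these two groups here. Within the data shown here, this is the only reading of this position so far, and it rests on one pair. Nothing available bears on the reason for the step.

On these data alone, whether bromo, methyl or methoxy on the same carbon would match chloro remains open. So does the effect of hydrogen there, with no halogen at all.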